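Chloro in place of methoxy: expected standing of compound 4

The source may hold more compounds than are shown below. What is called first, only, known or untested is meant among the compounds shown, and "the series" means these compounds.

Compound 1 `COc1ccccc1/C=C/C(=O)c1nc2ccccc2[nH]1` gives 41300 nM in a functional assay on MCF7 cells (Homo sapiens) for antiproliferative activity, read by MTT assay, with a stated time of 48 h; a higher number here means a weaker inhibitor, a lower number a stronger inhibitor. Compound 2 `Cc1ccccc1/C=C/C(=O)c1nc2ccccc2[nH]1` gives 62500 nM in this assay. Compound 3 `COc1cccc(/C=C/C(=O)c2nc3ccccc3s2)c1` gives > 100000 nM in this assay.

Compound 3 stands only at a limit, not at a number: the limit of > 100000 nM in this assay, at which 1 of the 3 values shown sits. Compound 4 `O=C(/C=C/c1cccc(Cl)c1)c1nc2ccccc2s1` differs from compound 3 by chloro in place of methoxy on an aromatic carbon. Among the compounds with values here, the one measured step that bears on this exchange is a 1.5-fold higher number from compound 1 to compound 2 (0.18 log units; within the scatter), where methoxy on an aromatic carbon also gives way to a small group, on another core, and the step stays within the scatter. No step beyond the scatter is therefore expected here; the step from compound 3 to compound 4 is expected to be a number no higher from compound 3 to compound 4 (the limit leaves the size open). Compound 4 is estimated at 100000 nM, with a range from 40000 nM to 250000 nM, and a limit rather than a number is the likelier outcome.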

Compound 4, half-maximal inhibitory concentration: > 100000 nM
Compound 4: only a limit was reported; the forecaster's own chance of this, stated with the estimate: 60%; the middle value sits exactly at the limit.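

No step between compound 3 and compound 4 can be read, since both stand only at a limit in this assay: the limit of > 100000 nM in this assay, at which 2 of the 4 values shown sit.

The compounds shown leave open how chloro and methoxy compare on the core of compound 3.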